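The source may hold more compounds than are shown below. What is called first, only, known or untested is meant among the compounds shown, and "the series" means these compounds.

Working notes on the series.

Within the data shown here, compound 3 `O=C(CCc1ccc(-c2ccccc2)cc1)c1ncc(C(=O)C(F)(F)F)o1` stands second highest of the three numbers so far in an assay for inhibition of Fatty-acid amide hydrolase 1 (Rattus norvegicus) (a higher number here means a weaker inhibitor, a lower number a stronger inhibitor), where compound 3 gives 8 nM. The nearest neighbour is compound 1 `O=C(CCc1ccc(-c2ccccc2)cc1)c1ncc(-c2ccncc2)o1`, which in this assay gives 2.3 nM; the furthest is compound 2 `O=C(O)c1cc(-c2cnc(C(=O)CCc3ccc(-c4ccccc4)cc3)o2)ccn1`, which gives 50 nM.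

Compound 4 `COC(=O)c1ccc(-c2cnc(C(=O)CCc3ccc(-c4ccccc4)cc3)o2)cn1` differs from compound 3 by 6-(methoxycarbonyl)pyridin-3-yl in place of (trifluoromethyl)carbonyl on an aromatic carbon. Among the measured compounds shown here, two measured steps bear on a pyridyl group in this position. The step of a 3.5-fold higher number from compound 1 to compound 3 (0.54 log units; beyond the scatter) shows that a plain pyridin-4-yl is favoured over the (trifluoromethyl)carbonyl. The step of a 6.3-fold lower number from compound 2 to compound 3 (0.80 log units; beyond the scatter) shows the reverse when the pyridyl carries a carboxy group. The incoming 6-(methoxycarbonyl)pyridin-3-yl is a pyridyl ring with an ester rather than a carboxy, and its attachment differs from both measured pyridyls, so neither step transfers directly; the expectation is a step of modest size at most, in either direction.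

For compound 4 the estimate is 10 nM with a range of 2 nM to 50 nM, meaning an expected step of a 1.3-fold higher number from compound 3 to compound 4 (0.10 log units; within the scatter).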

Compound 4, inhibition constant: 0.6 nM
Compound 4: the middle estimate sits 17-fold (1.22 log units) above what was measured, and the stated range ends above it.
By their numbers in this assay, from the lowest: compound 4; then compound 1; then compound 3; then compound 2.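

In this assay, a 13-fold lower number from compound 3 to compound 4 (1.12 log units; beyond the scatter) and a 3.8-fold lower number from compound 1 to compound 4 (0.58 log units; beyond the scatter) show that a pyridyl ring carrying a substituent at this position, on the aromatic carbon next to the ring oxygen, need not cost anything, and compound 4 is the strongest of the four. The larger 83-fold lower number from compound 2 to compound 4 (1.92 log units; beyond the scatter) joins two changes, carboxy to methoxycarbonyl and pyridin-4-yl to pyridin-3-yl attachment, so it cannot be credited to either one alone. Nothing shown here gives a reason for these steps.

The compounds shown do not separate the contribution of the methoxycarbonyl from that of the ring attachment. A plain pyridin-3-yl, or a carboxylic acid or primary amide at the same place on the pyridin-3-yl ring, would divide the two.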